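The source may report more compounds than this note shows. Statements on the series, on what has been measured and on what is new or still open speak of the compounds shown alone.

Measured so far in an assay on HEK293 cells for positive allosteric modulation of metabotropic glutamate receptor 5 (Homo sapiens), read by FLIPR, with a stated time of 1 h; on this read-out lower numbers stand for an effect already at smaller amounts and higher numbers for an effect only at larger amounts of compound:
Compound 1 `O=C1NCCc2nc(C#Cc3ccccc3F)sc21` gives 1500 nM.
Compound 2 `COC1CC(C(=O)N2CCc3nc(C#Cc4ccccc4)sc3C2)C1` gives 640 nM.

Compound 2 holds the lower of the two numbers in this assay; compound 1 stands higher by a margin beyond the usual scatter. Within the data shown here, the two compounds differ in more than one place, so no single step is drawn between them, and only the two values themselves can be read.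

The next compound, compound 3 `Cc1nc(C(=O)N2CCc3nc(C#Cc4ccccc4)sc3C2)cs1`, keeps the shared core of compound 2 and changes one place:

2-methyl-1,3-thiazol-4-yl in place of 3-methoxycyclobutyl on a carbonyl carbon

Among the measured compounds shown here, no measured pair shows this exchange, so the size of the step is not known from data. The expectation is for a small step in this assay, within or just beyond the scatter, with no firm direction; a modest move toward a lower number is taken as slightly more likely than a move upward. Compound 3 is estimated at 500 nM, with a range from 150 nM to 2000 nM. The step that this estimate means is a 1.3-fold lower number from compound 2 to compound 3 (0.11 log units; within the scatter), expected rather than measured.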

Compound 3, half-maximal effective concentration: 220 nM
Beside the measured number, compound 3's estimate is 2.3-fold (0.36 log units) above it, within the range that was stated.
By their numbers in this assay, from the lowest: compound 3; then compound 2; then compound 1.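

In this assay, among these compounds, the exchange of 3-methoxycyclobutyl for 2-methyl-1,3-thiazol-4-yl on a carbonyl carbon gives a 2.9-fold lower number from compound 2 to compound 3 (0.46 log units; beyond the scatter) and is the first single-place step, one that lies beyond the usual scatter. The position on this carbonyl therefore responds to the group it carries, which compound 1 and compound 2 alone could not show, as they differ in more than one place. The two groups match in heavy-atom count, and the lower number comes with the five-membered aromatic ring with 2 hetero atoms rather than the four-membered ring of carbon only, although no measurement on hand bears on why the number moves.

Among the compounds shown here, whether the step belongs to the ring as a whole, to its methyl or to its hetero atoms stays open, as only a single aromatic group stands at this place so far. Also open, on these data alone, is how an unsubstituted thiazole, a phenyl, a dimethylamino group or a longer alkyl chain on the same carbonyl carbon would read in this assay on this core.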